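Aryl swap at the hydrazone end of compound 2

This account rests on a few compounds, and the source may have more. Where it says the series, first, only, none or still open, it means among the compounds named here.

For the measured compounds named here, compound 2 `COc1cc2c(Oc3ccc(NC(=O)N/N=C/c4ccc(C(F)(F)F)cc4)cc3F)ccnc2cc1OCCCN1CCCCC1` gives the lowest of the two numbers so far in a functional assay on MKN-45 cells (Homo sapiens) for cytotoxicity, read by MTT assay, with a stated time of 72 h (on this read-out lower numbers stand for stronger inhibition and higher numbers for weaker inhibition), at 630 nM. Its nearest neighbour, compound 1 `COc1cc2c(Oc3ccc(NC(=O)N/N=C/c4ccc(C(F)(F)F)cc4)cc3F)ccnc2cc1OCCCN1CCCC1`, gives 1300 nM in this assay. Going by the values given here, the only one-place step measured, a 2.1-fold lower number from compound 1 to compound 2 (0.31 log units; beyond the scatter), concerns the amine at the end of the chain and not the aryl group. Compound 3 `COc1cc2c(Oc3ccc(NC(=O)N/N=C/c4ccc(Cl)cc4Cl)cc3F)ccnc2cc1OCCCN1CCCCC1` differs from compound 2 in one place: 2,4-dichlorophenyl in place of 4-(trifluoromethyl)phenyl on a carbon with a double bond to nitrogen. Among the compounds with values here, no measured step touches this position, and the single step measured does not bear on it, so there is nothing on which to scale the change. The expected step, no change at the digits printed from compound 2 to compound 3 (within the scatter), lies within the scatter of this assay. Within the data shown here, the estimate for compound 3 is 630 nM, with a range from 200 nM to 2000 nM; the range is set wide, as no measured step covers this position.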

Compound 3, half-maximal inhibitory concentration: 460 nM
For compound 3 the middle estimate is 1.4-fold (0.14 log units) above the measured one, within the range that was stated.
By their numbers in this assay, from the lowest: compounds 3 and 2 (each within the scatter of the next); then compound 1.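

In this assay, for the compounds shown here, the one measured change at this position is a 1.4-fold lower number from compound 2 to compound 3 (0.14 log units; within the scatter), so the step stays within the scatter. On a carbon with a double bond to nitrogen, 2,4-dichlorophenyl and 4-(trifluoromethyl)phenyl cannot be told apart in this read-out, which shows that this replacement of one substituted phenyl group by another leaves the cell result unresolved from that of compound 2. No supporting measurement bears on why the two groups read alike.

On these data alone, both groups are phenyl rings carrying halogen-containing substituents, so it remains open how an unsubstituted phenyl, a pyridine ring or a phenyl bearing an amine or a carboxylic acid would read here. As far as these compounds go, it is also open whether the pyrrolidin-1-yl to piperidin-1-yl step carries over with 2,4-dichlorophenyl in place.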